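The compounds below may be only part of what the source reports. "The series", "measured", "known", "first", "only" and "open" are said of these compounds alone.

Among the compounds with values here, in a functional assay on DLD-1 cells (Homo sapiens) for inhibition, read by crystal violet staining and colony formation, with stated times of 72 h and 7 days (on this read-out lower numbers stand for an effect already at smaller amounts and higher numbers for an effect only at larger amounts of compound), compound 3 `O=C(Nc1ccc(Sc2nc3ccccc3s2)c(Cl)c1)c1cccc(Br)c1O` gives 21000 nM, the only actual number among the measured compounds. Compound 1 `COc1ccc(S(=O)(=O)Nc2ccc3oc(-c4ccc(NC(=O)c5cccc(C)c5[N+](=O)[O-])cc4)nc3c2)cc1` reads > 50000 nM, which is a limit of the assay and not a number. Compound 2 `COc1ccc(S(=O)(=O)Nc2ccc3oc(-c4ccc(NC(=O)c5ccc(Cl)s5)cc4)nc3c2)cc1` reads > 50000 nM, which is likewise a limit. Compound 4 `COc1c(Br)cccc1C(=O)Nc1ccc(Sc2nc3ccccc3s2)c(Cl)c1` differs from compound 3 by methyl in place of hydrogen on an oxygen on an aromatic ring, a change of hydroxy to methoxy, with methyl in place of hydrogen on an oxygen on an aromatic ring. Within the data shown here, the sole measured step, a step that the two limits leave unreadable from compound 1 to compound 2, concerns a different change, so it offers no size to carry over. The estimated step is a 1.7-fold higher number from compound 3 to compound 4 (0.22 log units; within the scatter), a tentatively expected modest loss of effect. For compound 4 the expected value is 35000 nM, with an estimated range of 14000 nM to 50000 nM.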

Compound 4, half-maximal effective concentration: 11000 nM
For compound 4 the middle estimate is 3.2-fold (0.50 log units) above the measured one; measured number outside the range, below it.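

In this assay, methyl in place of hydrogen on an oxygen on an aromatic ring gives a 1.9-fold lower number from compound 3 to compound 4 (0.28 log units; within the scatter), so hydroxy and methoxy cannot be told apart here. Within the data shown here, this is the first step with a readable size, and both compounds carry actual numbers rather than a limit. No measurement shown bears on a cause for this step.

What the compounds shown leave open is whether a longer chain on that oxygen, such as propoxy, would also stay within the scatter. On these data alone, an amine in place of the hydroxy is equally open.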